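Swapping the Aryl Group on a Triazole Ring

This account rests on a few compounds, and the source may have more. Where it says the series, first, only, none or still open, it means among the compounds named here.

Of the compounds shown here, three have been measured in a functional assay on A549 cells (Homo sapiens) for cytotoxicity, read by MTT assay, with a stated time of 48 h; a higher number here means a weaker inhibitor, a lower number a stronger inhibitor. Compound 1 `CC(C)=CCC/C(C)=C/CC/C(C)=C/CC[C@@H]1[C@@]2(C)CC/C(=N\OCc3cn(-c4ccc(F)c(Cl)c4)nn3)C(C)(C)[C@@H]2CC[C@@]1(C)O` gives 21400 nM in this assay. Compound 2 `CC(C)=CCC/C(C)=C/CC/C(C)=C/CC[C@@H]1[C@@]2(C)CC/C(=N\OCc3cn(-c4c(Cl)cc([N+](=O)[O-])cc4Cl)nn3)C(C)(C)[C@@H]2CC[C@@]1(C)O` differs from it by one change, (2,6-dichloro-4-nitrophenyl in place of 3-chloro-4-fluorophenyl on an aromatic nitrogen), and in this assay compound 2 gives 11200 nM. That step, a 1.9-fold lower number from compound 1 to compound 2 (0.28 log units; within the scatter), is small. Compound 3 `CC(C)=CCC/C(C)=C/CC/C(C)=C/CC[C@@H]1[C@@]2(C)C/C(=C\c3ccc(OCc4cn(-c5ccc(F)c(Cl)c5)nn4)cc3)C(=O)C(C)(C)[C@@H]2CC[C@@]1(C)O` is built on a different core, and the difference between the two cores is not broken down here; in this assay compound 3 gives 46600 nM, the highest of the three numbers, and its gaps to compound 1 and to compound 2 are both beyond the scatter.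

Compound 4 `CC(C)=CCC/C(C)=C/CC/C(C)=C/CC[C@@H]1[C@@]2(C)C/C(=C\c3ccc(OCc4cn(-c5c(Cl)cc([N+](=O)[O-])cc5Cl)nn4)cc3)C(=O)C(C)(C)[C@@H]2CC[C@@]1(C)O` has not yet been measured. It stands to compound 3 as compound 2 stands to compound 1: 2,6-dichloro-4-nitrophenyl in place of 3-chloro-4-fluorophenyl on an aromatic nitrogen. The place of the change is the same in both pairs, so this is the same change made on a second core. The step from compound 3 to compound 4 is expected to be small, roughly a 1.7-fold lower number from compound 3 to compound 4 (0.22 log units; within the scatter), because a 1.9-fold lower number from compound 1 to compound 2 (0.28 log units; within the scatter) stayed within the scatter. Compound 4 is therefore expected to give about 28000 nM in this assay, with an estimated range from 12000 nM to 65000 nM.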

Compound 4, half-maximal inhibitory concentration: 34700 nM
The estimate for compound 4 lay 1.2-fold (0.09 log units) below the measured number; measured number inside the range.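

On the second core the change again gives only a small step in this assay, a 1.3-fold lower number from compound 3 to compound 4 (0.13 log units; within the scatter). Set side by side, the two steps agree as closely as this kind of measurement can tell: the same change on two cores in this assay, a 1.9-fold lower number (0.28 log units; within the scatter) from compound 1 to compound 2 and a 1.3-fold lower number (0.13 log units; within the scatter) from compound 3 to compound 4, 1.4-fold (0.15 log units) apart, within the scatter of two such steps. In these two pairs, then, the change carries from one core to the other without a visible difference, but both steps lie within the scatter, so this does not show that the change has a real effect on either core, and two cores cannot speak for others in the series.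

The compounds shown leave open whether a different group on that aromatic nitrogen, such as a plain phenyl, a benzyl or a phenyl bearing an amine or a carboxylic acid, would move the number beyond the scatter on either core. Also open, on these data alone, is what a longer chain between that ring and the rest of the molecule would do.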